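A few compounds are considered here, and "the series" means these few. Any claim that something is new, unique, unknown or untested is made for them only; others in the source may bear on it.

Series notes, step from compound 2 to compound 3.

Two members have numbers in a functional assay on the whole organism (stomach) for inhibition, with Canis familiaris (Canis lupus familiaris) as the target, at a dose of 20 mg/kg by the oral route; on this read-out lower numbers stand for a weaker effect and higher numbers for a stronger effect at the one dose given. Compound 1 `Cc1cc(C)nc(N(CCNC(C)C)C(=O)N(C)C)c1` gives 33%. Compound 2 `Cc1cc(C)nc(N(CCN(C)C)C(=O)N(C)C)c1` gives 58%, the highest of the two numbers; its nearest neighbour is compound 1, which lies a step beyond the scatter away. Among the compounds with values here, the one step between the measured compounds, a number 25 percentage points higher from compound 1 to compound 2 (beyond the scatter), concerns the same position as the change examined here.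

Compound 3 `CCCN(CCC)CCN(C(=O)N(C)C)c1cc(C)cc(C)n1` is not yet measured in this assay. It differs from compound 2 thus: dipropylamino in place of dimethylamino on a saturated chain carbon, two bonds along the chain from an amide-type nitrogen.

Within the data shown here, only the step from compound 1 to compound 2 bears on this change, and it was modest; it does not concern the dipropylamino group itself, so it sets direction poorly. For compound 3 a number somewhat lower than that of compound 2 is expected, a step of a number 13 percentage points lower from compound 2 to compound 3 (beyond the scatter), though a result within the scatter cannot be ruled out. The estimate for compound 3 is 45%, within the range 20% to 70%.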

Compound 3, a percentage reported as inhibition, in the whole organism at one dose (the size of the read-out at that dose, not a potency): 22%
Compound 3: middle estimate off by 23 percentage points, on the high side; the measured number falls inside the stated range.
By their numbers in this assay, from the lowest: compound 3; then compound 1; then compound 2.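

In this assay, within the data shown here, this position proves more sensitive than the earlier compounds showed: replacing dimethylamino with dipropylamino gives a number 36 percentage points lower from compound 2 to compound 3 (beyond the scatter), a large step where the earlier one was modest. Dipropylamino also falls short of isopropylamino, with a number 11 percentage points lower from compound 1 to compound 3 (beyond the scatter), so among these three compounds the order runs from dimethylamino at the top through isopropylamino to dipropylamino at the bottom, and none goes against it. No available data give a reason for this order.

The compounds shown leave open where diethylamino would fall in this order, and whether a ring amine such as pyrrolidine or piperidine would hold the number of compound 2 or lose it. Unsubstituted amino at this position also remains an open comparison with isopropylamino.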